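Adding a Methoxy Group to a Chalcone-Type Antiproliferative Scaffold

This account rests on a few compounds, and the source may have more. Where it says the series, first, only, none or still open, it means among the compounds named here.

Measured compounds:
compound 1, `COc1ccc(/C=C/C(=O)c2ccccc2-c2ccc(OC)c(OC)c2)cc1`, 1600 nM
compound 2, `COc1ccc(/C=C/C(=O)c2ccccc2-c2ccc(OC)c(OC)c2)cc1OC`, 8500 nM
compound 3, `O=C(/C=C/c1ccccc1-c1ccc(F)cc1)c1cccc(O)c1`, 6900 nM

In a functional assay on A549 cells (Homo sapiens) for antiproliferative activity, read by sulforhodamine B assay, with a stated time of 48 h (on this read-out higher numbers stand for weaker inhibition and lower numbers for stronger inhibition), compound 1 gives 1600 nM, while compound 2 gives 8500 nM. The step between them, (methoxy in place of hydrogen on an aromatic carbon), led to a 5.3-fold higher number from compound 1 to compound 2 (0.73 log units; beyond the scatter). Compound 3 gives 6900 nM in this assay; the difference between its core and the core of compound 1 is not broken down here.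

The unmeasured compound 4, `COc1ccc(C(=O)/C=C/c2ccccc2-c2ccc(F)cc2)cc1O`, carries the same kind of change relative to compound 3: methoxy in place of hydrogen on an aromatic carbon. The surroundings are not identical, though. In compound 2 the new group sits ortho to a methoxy group and meta to a large group, whereas in compound 4 it sits ortho to a hydroxy group and para to a large group.

Resting on the single earlier example, a weakening of similar size is expected, so compound 4 is estimated at 14000 nM in this assay, with a plausible range of 3500 nM to 45000 nM. That expectation means a step of a 2.0-fold higher number from compound 3 to compound 4 (0.31 log units; beyond the scatter) from compound 3 to compound 4, with wide uncertainty since the places differ.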

Compound 4, half-maximal inhibitory concentration: 940 nM
Compound 4: middle estimate off by 15-fold (1.17 log units), on the high side; the whole stated range lies above it.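

Carrying the change onto the core of compound 3 reverses its direction: in this assay, replacing hydrogen with methoxy gives a 7.3-fold lower number from compound 3 to compound 4 (0.87 log units; beyond the scatter). Set side by side, the two steps do not agree: the same change on two cores in this assay, a 5.3-fold higher number (0.73 log units; beyond the scatter) from compound 1 to compound 2 and a 7.3-fold lower number (0.87 log units; beyond the scatter) from compound 3 to compound 4, 39-fold (1.59 log units) apart, beyond the scatter of two such steps. This shows that the step measured on the core of compound 1 cannot be used to predict the result of the same change on the core of compound 3, but it does not show what causes the reversal, as the two pairs differ both in their cores and in the groups surrounding the new methoxy.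

Going by these compounds, it remains open whether the lower number of compound 4 depends on the methoxy sitting ortho to a hydroxy group, or would also appear with the methoxy elsewhere on that ring. Also open, on these data alone, is whether an ethoxy group or an amine in the same place would follow the step to compound 4 or the step to compound 2.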